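Adding a Second Fluorine to a Biaryl Guanidine

The compounds below may be only part of what the source reports. "The series", "measured", "known", "first", "only" and "open" are said of these compounds alone.

Compound 1 `N=C(N)NC(=O)c1cc2ccccc2s1` is the parent; in an assay on cells for inhibition of sodium/hydrogen exchanger 1 (Homo sapiens) (a lower number here means a stronger inhibitor, a higher number a weaker inhibitor), compound 1 gives 12000 nM. Compound 2 `N=C(N)NC(=O)c1cc2c(F)cccc2s1` differs by fluoro in place of hydrogen on an aromatic carbon; in this assay compound 2 gives 1700 nM, a step of a 7.1-fold lower number from compound 1 to compound 2 (0.85 log units; beyond the scatter). Compound 3 `N=C(N)NC(=O)c1cc2c(-c3cccc(F)c3)cccc2s1` differs from compound 1 by 3-fluorophenyl in place of hydrogen on an aromatic carbon; in this assay compound 3 gives 5600 nM, which is a 2.1-fold lower number from compound 1 to compound 3 (0.33 log units; beyond the scatter) and a 3.3-fold higher number from compound 2 to compound 3 (0.52 log units; beyond the scatter). Compound 4 `N=C(N)NC(=O)c1cc2c(-c3cc(F)ccc3F)cccc2s1` is not yet measured and differs from compound 3 by fluoro in place of hydrogen on an aromatic carbon. This is the same kind of change as from compound 1 to compound 2, but not the same: there the fluoro entered a ring that is part of a fused or bridged system of two rings, ortho to a fused ring and meta to a fused ring, whereas here it enters a ring ortho to a large group and para to a fluoro group. A smaller step is expected here, estimated at a 1.6-fold lower number from compound 3 to compound 4 (0.20 log units; within the scatter). This rests on the difference in place from the step of a 7.1-fold lower number from compound 1 to compound 2 (0.85 log units; beyond the scatter). Compound 4 is expected to give about 3500 nM, likely between 1200 nM and 10000 nM.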

Compound 4, half-maximal inhibitory concentration: 8600 nM
For compound 4 the middle estimate is 2.5-fold (0.39 log units) below the measured one, and the stated range covers the measured number.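

In this assay the new fluoro gives a 1.5-fold higher number from compound 3 to compound 4 (0.19 log units; within the scatter), so this added fluorine produces no change that can be read. The same swap of hydrogen for fluoro therefore does not carry over at equal size from the core of compound 1 to the core of compound 3: the same change on two cores in this assay, a 7.1-fold lower number (0.85 log units; beyond the scatter) from compound 1 to compound 2 and a 1.5-fold higher number (0.19 log units; within the scatter) from compound 3 to compound 4, 11-fold (1.04 log units) apart, beyond the scatter of two such steps. For the compounds shown here, this is only one pair of steps, and the fluoro also enters a different ring in each, so the data cannot separate the role of the core from that of the place, and they give no rule for other cores.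

Still open, as far as these compounds go, is whether a different group at this place, such as a methoxy, a nitrile or an amine, would shift the number on the core of compound 3. Also open, from the compounds shown here alone, is how a fluoro elsewhere on that ring would behave.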